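The source may hold more compounds than are shown below. What is called first, only, known or untested is meant among the compounds shown, and "the series" means these compounds.

The series shares the core of compound 1 `CC1CCC(=NNc2ccccc2)c2ncc(C(=O)NO)c(=O)n21`. In a functional assay on the whole organism with Rattus norvegicus as the target (on this read-out lower numbers stand for an effect already at smaller amounts and higher numbers for an effect only at larger amounts of compound), compound 1 gives > 100 umol/kg, which is a limit of the measurement and not a number. Compound 2 `Cc1cccc(C)c1NN=C1CCC(C)n2c1ncc(C(=O)O)c2=O` carries a 2,6-dimethylphenyl on the amine nitrogen; in this assay compound 2 gives 320 umol/kg. Compound 3 `Cc1cc(C)c(NN=C2CCC(C)n3c2ncc(C(=O)O)c3=O)c(C)c1` has a methyl in place of hydrogen on an aromatic carbon, and in this assay compound 3 gives 320 umol/kg. Among the numbers shown, compound 2 stands level with compound 3, its nearest neighbour, and the one further value is a limit; the single measured step, no change at the digits printed from compound 2 to compound 3 (within the scatter), lies within the scatter. The limit itself is described by the limit of > 100 umol/kg in this assay, at which 1 of the 3 values shown sits.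

Compound 4 `CC1CCC(=NNc2cc(Cl)ccc2O)c2ncc(C(=O)O)c(=O)n21` differs from compound 2 in one place: 5-chloro-2-hydroxyphenyl in place of 2,6-dimethylphenyl on an amine nitrogen. Within the data shown here, no measured step touches a hydroxyl or a chlorine on this ring, so the only guide is the flat methyl step, which gives no direction to lean on. Among the measured compounds shown here, the expected step of no change at the digits printed from compound 2 to compound 4 (within the scatter) is therefore one that stays within the scatter, with a broad range because no change at the digits printed from compound 2 to compound 3 (within the scatter) is the only measured comparison. Compound 4 is expected to give about 320 umol/kg in this assay, with a range from 110 umol/kg to 900 umol/kg.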

Compound 4, dose for 50% inhibition: > 100 umol/kg
Compound 4 ended at the assay's limit; the forecaster's own chance of this, stated with the estimate: 20%; the middle value is on the limit's open side.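

In this assay compound 4 gives > 100 umol/kg, which is a limit and not a number, so no step to it from compound 2 can be read: the limit of > 100 umol/kg in this assay, at which 2 of the 4 values shown sit.

The compounds shown leave open how 5-chloro-2-hydroxyphenyl on the amine nitrogen compares in size of effect with 2,6-dimethylphenyl.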